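Compound 1 to compound 4: isopentyloxy to propoxy

The compounds below may be only part of what the source reports. "The series", "measured", "known", "first", "only" and "open" are said of these compounds alone.

Within the data shown here, in a functional assay on MCF7 cells (Homo sapiens) for antiproliferative activity, read by sulforhodamine B assay, with a stated time of 3 days (a lower number here means that less compound is needed, a higher number that more compound is needed for the effect), compound 1 (`CCCC1=C(OCCC(C)C)C(CCC)(CCC)C(=O)/C(=C(O)\C=C\c2ccccc2)C1=O`) gives 9.1 uM and sits within the scatter of compound 3 (`COC1=C(CC=C(C)C)C(=O)/C(=C(O)/C=C/c2ccccc2)C(=O)C1(CC=C(C)C)CC=C(C)C`), which gives 8.2 uM as the only other number. Compound 2 (`CCCC1=C(OC)C(CCC)(CCC)C(=O)/C(=C(O)\C=C\c2ccc(Br)cc2)C1=O`) offers no comparison: its result stands as "not determined" (no result reported) in the series. Compound 4 (`CCCOC1=C(CCC)C(=O)/C(=C(O)/C=C/c2ccccc2)C(=O)C1(CCC)CCC`) awaits measurement. It differs from compound 1 as isopentyloxy to propoxy (methyl in place of isopropyl on a saturated chain carbon, two bonds along the chain from an oxygen on an unsaturated carbon), with methyl in place of isopropyl on a saturated chain carbon, two bonds along the chain from an oxygen on an unsaturated carbon. Among the measured compounds shown here, no measured pair isolates this change, so no step beyond the scatter is expected in this assay for it. The estimated change runs a 1.1-fold higher number from compound 1 to compound 4 (0.04 log units; within the scatter) and stays within the scatter. Compound 4 is expected at 10 uM with 5 uM to 20 uM as its estimated range.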

Compound 4, concentration for half-maximal effect: 1.6 uM
Beside the measured number, compound 4's estimate is 6.3-fold (0.80 log units) above it, outside the stated range (below it).
By their numbers in this assay, from the lowest: compound 4; then compounds 3 and 1 (each within the scatter of the next).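

In this assay, among these compounds, the change from isopentyloxy to propoxy gives the first readable step, a 5.7-fold lower number from compound 1 to compound 4 (0.75 log units; beyond the scatter), with methyl in place of isopropyl on a saturated chain carbon. The number at this position therefore responds to the chain, though this rests on a single pair. Nothing measured on these compounds bears on why the number moves. From the compounds shown here alone, whether the trend continues with ethoxy or reverses with a longer chain such as hexyloxy remains open. So does the effect of an aminoethoxy group in place of propoxy.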